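The source may hold more compounds than are shown below. What is called first, only, known or untested is meant among the compounds shown, and "the series" means these compounds.

Measured so far in an assay for binding affinity to Amine oxidase [flavin-containing] A (Homo sapiens); a higher number here means a weaker inhibitor, a lower number a stronger inhibitor:
compound 1 `O=Cc1cn(C[C@H]2CN(c3ccc(C4=CCS(=O)(=O)CC4)c(F)c3)C(=O)O2)nn1`, 3200 nM
compound 2 `Cc1cnnn1C[C@H]1CN(c2ccc(C3=CCS(=O)(=O)CC3)c(F)c2)C(=O)O1`, 4500 nM

Compound 2 carries the higher of the two numbers in this assay, with compound 1 as its nearest neighbour at a gap within the scatter. Compound 3 `O=C1O[C@@H](Cn2ccnn2)CN1c1ccc(C2=CCS(=O)(=O)CC2)c(F)c1` differs from compound 2 by hydrogen in place of methyl on an aromatic carbon. Among the measured compounds shown here, the one measured step with a bearing on this change is the exchange of the group on the same ring, a 1.4-fold higher number from compound 1 to compound 2 (0.15 log units; within the scatter), which stayed within the scatter. On that basis no step beyond the scatter is expected in this assay, and the estimated change is a 1.1-fold lower number from compound 2 to compound 3 (0.05 log units; within the scatter). For compound 3 the expected value in this assay is 4000 nM, with a range from 1500 nM to 11000 nM.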

Compound 3, inhibition constant: 3400 nM
Compound 3: middle estimate off by 1.2-fold (0.07 log units), on the high side; the measured number falls inside the stated range.
By their numbers in this assay, from the lowest: compounds 1, 3 and 2 (each within the scatter of the next).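

In this assay, hydrogen in place of methyl on the aromatic carbon gives a 1.3-fold lower number from compound 2 to compound 3 (0.12 log units; within the scatter) and hydrogen in place of formyl gives a 1.1-fold higher number from compound 1 to compound 3 (0.03 log units; within the scatter) in the same series. With hydrogen now measured on this triazole, neither methyl nor formyl separates from it beyond the scatter. No measurement on hand accounts for this result. Open, from the compounds shown here alone, is whether an amine, a carboxylic acid or phenyl on this ring would give a step beyond the scatter. Going by these compounds, whether the same holds on a core other than the shared one also remains open.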